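The compounds below may be only part of what the source reports. "The series", "measured", "known", "first", "only" and "open" are said of these compounds alone.

Measured compounds:
compound 1 `CCn1cccc(-c2ccc(N3C[C@H](CNC(=O)c4ccc(Cl)s4)OC3=O)cc2OC)c1=O`, 61 nM;
compound 2 `COc1cc(C(=O)N2CC[C@@H](O)C(C)(C)C2)cc2nc(NCc3cccc(Cl)c3)oc12`, 35 nM;
compound 3 `COc1cc(C(=O)N2CCC(O)C(C)C2)cc2nc(NCc3ccnc(Cl)c3)oc12`, 6900 nM.

In an assay on isolated protein for inhibition of thyroid hormone receptor beta (Homo sapiens), read by fluorescence, with a stated time of 30 min (on this read-out lower numbers stand for stronger inhibition and higher numbers for weaker inhibition), compound 3 stands highest of these three numbers, well beyond the scatter from both compound 1 and compound 2. Compound 4 `COc1cc(C(=O)N2CCC(O)C(C)C2)cc2nc(NC3(c4cccc(Cl)c4)CC3)oc12` is compound 3 with one change: 1-(3-chlorophenyl)cyclopropyl in place of (2-chloropyridin-4-yl)methyl on a nitrogen on an aromatic ring. For the measured compounds named here, no measured pair shows this change alone, so its size is uncertain. The estimate for compound 4 leans toward a lower number, because compound 2, which also carries a chlorophenyl group on that nitrogen, gives 35 nM even though it differs from compound 4 elsewhere. The expected step from compound 3 to compound 4 is a 17-fold lower number from compound 3 to compound 4 (1.24 log units; beyond the scatter). Compound 4 is therefore estimated at 400 nM, with a range from 60 nM to 2500 nM.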

Compound 4, half-maximal inhibitory concentration: 120 nM
Compound 4: the middle estimate sits 3.3-fold (0.52 log units) above what was measured, and the stated range covers the measured number.
By their numbers in this assay, from the lowest: compounds 2, 1 and 4 (each within the scatter of the next, the first and the last beyond it); then compound 3.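

In this assay, the group on this nitrogen matters a great deal: 1-(3-chlorophenyl)cyclopropyl in place of (2-chloropyridin-4-yl)methyl gives a 58-fold lower number from compound 3 to compound 4 (1.76 log units; beyond the scatter). This single change swaps the ring nitrogen for carbon and also adds a three-membered ring, so two features change together. No measurement shown gives a reason for this step.

Which of the two features carries the step remains open. A 1-(2-chloropyridin-4-yl)cyclopropyl group on the same nitrogen would keep the three-membered ring and the ring nitrogen together, and so help tell them apart.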